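This account rests on a few compounds, and the source may have more. Where it says the series, first, only, none or still open, it means among the compounds named here.

Measured compounds:
compound 1 `NCCn1ncc2c(NCc3ccccc3[N+](=O)[O-])cc(C(F)(F)F)cc21`, 29%
compound 2 `O=[N+]([O-])c1ccc2[nH]c(CNc3cc(C(F)(F)F)cc4[nH]ncc34)cc2c1`, 69%
compound 3 `CNC(=O)c1cccc(CNc2cc(C(F)(F)F)cc3[nH]ncc23)c1`, 91%

All three were tested in an assay for inhibition of Tryptophan 2,3-dioxygenase (Homo sapiens), with stated times of 10 min and 60 min, tested at 100 uM; a higher number here means a stronger effect of the compound at the concentration tested, a lower number a weaker effect. Compound 1 stands lowest of the three. In this assay compound 2 gives 69%, a number beyond the scatter above that of compound 1, and compound 3 gives 91%, further still above compound 1. Both compound 2 and compound 3 differ from compound 1 in more than one place, so no single change can be read from them.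

The unmeasured compound 4 `O=[N+]([O-])c1ccccc1CNc1cc(C(F)(F)F)cc2[nH]ncc12` differs from compound 1 in one place only: hydrogen in place of 2-aminoethyl on an aromatic nitrogen. After the change the aromatic nitrogen of the five-membered ring carries hydrogen, as it does in compound 2 and compound 3.

For compound 4 a step upward in this assay, beyond the scatter, is expected, a number 26 percentage points higher from compound 1 to compound 4 (beyond the scatter). This expectation rests on the observation that compound 2 gives 69% and compound 3 gives 91% while both carry hydrogen on that nitrogen, though each also differs from compound 1 elsewhere. Compound 4 is therefore estimated at 55%, within a range from 30% to 80%.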

Compound 4, a percentage reported as inhibition, at one concentration (the size of the read-out at that concentration, not a potency): 95%
Compound 4: middle estimate off by 40 percentage points, on the low side, outside the stated range (above it).
By their numbers in this assay, from the lowest: compound 1; then compound 2; then compounds 3 and 4 (each within the scatter of the next).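

In this assay, going by these compounds alone, putting hydrogen in place of 2-aminoethyl on the aromatic nitrogen gives a number 66 percentage points higher from compound 1 to compound 4 (beyond the scatter) and is the only change here made in one place alone. It shows that this nitrogen of the five-membered ring is a sensitive position: with the rest of the molecule unchanged, the read-out moves far beyond the scatter, which compound 2 and compound 3 could not show, as each also differs from compound 1 elsewhere. Nothing available here explains why this change has so large an effect.

As far as these compounds go, only hydrogen and 2-aminoethyl can be compared at this nitrogen, so it remains open where a methyl group, an ethyl chain without the amine, or a chain ending in a carboxylic acid would fall. From the compounds shown here alone, it also remains open whether the same change would give a step of similar size with the other groups carried by compound 2 and compound 3.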